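The source may report more compounds than this note shows. Statements on the series, on what has been measured and on what is new or still open speak of the compounds shown alone.

Values measured in a functional assay on OVCAR-3 cells (Homo sapiens) for antiproliferative activity, read by MTT assay, with a stated time of 24 h; on this read-out lower numbers stand for stronger inhibition and higher numbers for weaker inhibition:
Compound 1 `O=C(NNc1ccc(F)cc1)c1ccccc1NS(=O)(=O)c1cnc(O)nc1O`: > 20000 nM, a limit of the assay and not a number
Compound 2 `Cc1ccc(C(=O)NNC(=O)c2ccccc2NS(=O)(=O)c2cnc(O)nc2O)cc1`: 12900 nM

Within the data shown here, compound 2 holds the only actual number in this assay so far, and it is a weak one on this scale. Compound 3 `O=C(NNC(=O)c1ccccc1NS(=O)(=O)c1cnc(O)nc1O)c1cccc(Cl)c1` has 3-chlorophenyl in place of 4-methylphenyl on a carbonyl carbon. Among the measured compounds shown here, only one measured step is available for comparison, an at least 1.5-fold lower number from compound 1 to compound 2 (0.19 log units; that floor lies within the scatter). That step lies within the scatter and makes a different exchange, so it gives no sign of a direction for the new one. The expected change is therefore none beyond the scatter, and the estimated step is a 1.1-fold lower number from compound 2 to compound 3 (0.03 log units; within the scatter). Compound 3 is expected to give about 12000 nM. The estimated range for compound 3 runs from 6000 nM to 25000 nM.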

Compound 3, half-maximal inhibitory concentration: 2080 nM
The estimate for compound 3 lay 5.8-fold (0.76 log units) above the measured number, outside the stated range (below it).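

In this assay, the group on this carbonyl carbon clearly matters: 3-chlorophenyl in place of 4-methylphenyl gives a 6.2-fold lower number from compound 2 to compound 3 (0.79 log units; beyond the scatter), even though both groups hold one six-membered aromatic ring of carbon only and neither has a hydrogen-bond donor or acceptor. The earlier step lay within the scatter, whereas the wider change from 4-fluorophenyl on an amine nitrogen to (3-chlorophenyl)carbonyl gives an at least 9.6-fold lower number from compound 1 to compound 3 (0.98 log units; beyond the scatter), also beyond the scatter. The size of that wider step is only a floor, as compound 1 stands at a limit of the assay and not at a number: the limit of > 20000 nM in this assay, at which 1 of the 3 values shown sits.

On these data alone, whether the stronger result comes from the chlorine itself or from where it sits stays open; 4-chlorophenyl and 3-methylphenyl would separate the two. How an amine or a carboxylic acid on the phenyl ring would fare is also unknown.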